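The source may report more compounds than this note shows. Statements on the series, on what has been measured and on what is new or still open speak of the compounds shown alone.

Measured compounds:
compound 1, `c1ccc2c(-c3cn4ccnc4c(-c4ccc5ncn(C6CCCCC6)c5c4)n3)cccc2c1`, 6.92%
compound 2, `Clc1ccc(-c2cn3ccnc3c(-c3ccc4ncn(C5CCCCC5)c4c3)n2)cc1`, 18.5%

Both compounds were tested in a functional assay on SR cells (Homo sapiens) for inhibition, read by sulforhodamine B assay, with a stated time of 48 h, tested at 10 uM; on this read-out higher numbers stand for more inhibition at the one concentration tested (going by the name of the read-out) and lower numbers for less inhibition. Compound 2 gives the higher of the two numbers; its nearest neighbour is compound 1, which lies a number 11.6 percentage points higher from compound 1 to compound 2 (beyond the scatter), a step beyond the usual scatter, brought about by 4-chlorophenyl in place of naphthalen-1-yl on an aromatic carbon.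

The next compound, compound 3, `c1csc(-c2cn3ccnc3c(-c3ccc4ncn(C5CCCCC5)c4c3)n2)c1`, differs from compound 2 in one place: thiophen-2-yl in place of 4-chlorophenyl on an aromatic carbon.

Within the data shown here, only one measured step exists, and it swaps one six-membered aromatic ring of carbon only for another on the same aromatic carbon; it does not show what a five-membered aromatic ring with one hetero atom does at that place. It does show that changing this group moved the number in this assay by a modest amount. A step of similar or smaller size is therefore expected here, in either direction, most likely near no change beyond the scatter. Compound 3 is thus estimated at 14%, with a range from 0% to 35%, which would mean an expected step of a number 4.5 percentage points lower from compound 2 to compound 3 (within the scatter).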

Compound 3, a percentage reported as inhibition, at one concentration (the size of the read-out at that concentration, not a potency): 27.2%
Beside the measured number, compound 3's estimate is 13.2 percentage points below it, and the stated range covers the measured number.
By their numbers in this assay, from the lowest: compound 1; then compounds 2 and 3 (each within the scatter of the next).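

This position accepts more than one kind of aromatic ring: in this assay, thiophen-2-yl in place of 4-chlorophenyl gives a number 8.7 percentage points higher from compound 2 to compound 3 (within the scatter) on this read-out, so a five-membered aromatic ring with 1 hetero atom and fewer heavy atoms cannot be told apart here from the six-membered ring of carbon only. Replacing naphthalen-1-yl with thiophen-2-yl gives a number 20.3 percentage points higher from compound 1 to compound 3 (beyond the scatter) and adds a second step beyond the scatter from that group, so among these three compounds, naphthalen-1-yl goes with the lowest number. No measurement of any property of these groups is available to explain these numbers.

The groups shown are all aromatic rings, so it remains open what an amine, a carboxylic acid or a longer chain would do on this aromatic carbon. On these data alone, it also remains open whether furan-2-yl, with oxygen in the place of sulfur, would match thiophen-2-yl, and how these compounds would compare at other concentrations, since one concentration shows the size of the read-out and not a potency.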